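Sulfonamide nitrogen substituents on the chromanone enamine core

This account rests on a few compounds, and the source may have more. Where it says the series, first, only, none or still open, it means among the compounds named here.

Measured compounds:
compound 1, `CCOC1Oc2ccccc2C(=O)/C1=C/Nc1ccc(S(N)(=O)=O)cc1`: 33400 nM
compound 2, `CCOC1Oc2ccccc2C(=O)/C1=C/Nc1ccc(S(=O)(=O)Nc2cc(C)on2)cc1`: 57200 nM

In a functional assay on A549 cells (Homo sapiens) for cytotoxicity, read by sulforhodamine B assay, with a stated time of 72 h (a higher number here means a weaker inhibitor, a lower number a stronger inhibitor), compound 1 gives 33400 nM and compound 2 gives 57200 nM. Compound 2 has the highest number of the two, but the step of a 1.7-fold higher number from compound 1 to compound 2 (0.23 log units; within the scatter) lies within the scatter, so the two cannot be ordered.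

Compound 3, `CCOC1Oc2ccccc2C(=O)/C1=C/Nc1ccc(S(=O)(=O)Nc2ncccn2)cc1`, is not yet measured. It differs from compound 2 in one place: pyrimidin-2-yl in place of 5-methyl-1,2-oxazol-3-yl on a sulfonamide nitrogen. Among the compounds with values here, no measured step swaps one ring for another on the sulfonamide nitrogen. Within the data shown here, the only step in hand, a 1.7-fold higher number from compound 1 to compound 2 (0.23 log units; within the scatter), shows that putting a five-membered heteroaryl ring on that nitrogen in place of hydrogen left the number within the scatter. A second ring of the same atom count replacing the first is therefore not expected to move the number beyond the scatter in either direction.

Compound 3 is estimated at 50000 nM, range 20000 nM to 150000 nM, an expected step of a 1.1-fold lower number from compound 2 to compound 3 (0.06 log units; within the scatter).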

Compound 3, half-maximal inhibitory concentration: > 100000 nM
Compound 3: a limit, no number (the forecaster's own chance of this, stated with the estimate: 20%); at least 2.0-fold (0.30 log units) between middle value and limit.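

In this assay compound 3 sits at a limit and not at a number: the limit of > 100000 nM in this assay, at which 1 of the 3 values shown sits.

Pyrimidin-2-yl in place of hydrogen on a sulfonamide nitrogen gives an at least 2.9-fold higher number from compound 1 to compound 3 (0.47 log units; beyond the scatter), the first step at this position that clears the scatter. The ring swap gives an at least 1.7-fold higher number from compound 2 to compound 3 (0.24 log units; that floor lies within the scatter), so only a floor is available and compound 2 and compound 3 cannot yet be separated, although the true step may be larger.

On these data alone, the size of the step from compound 2 to compound 3 stays open while compound 3 has only a limit. Also open, as far as these compounds go, is whether a small non-ring group on the sulfonamide nitrogen, such as methyl or acetyl, would stay within the scatter of compound 1 or shift the number as pyrimidin-2-yl does.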